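Dimethylamino ester tail added to compound 2

This account rests on a few compounds, and the source may have more. Where it says the series, first, only, none or still open, it means among the compounds named here.

Measured so far in an ADME assay on Raji cells (Homo sapiens) for cytotoxicity, read by luminescence, with a stated time of 72 h; on this read-out lower numbers stand for an effect already at smaller amounts and higher numbers for an effect only at larger amounts of compound (all three values are limits):
- compound 1 (`C=Cc1cccc(-c2[nH]c3cc(OC)ccc3c(=O)c2C(=O)OCC)c1`) gives > 21500 nM (limit)
- compound 2 (`CCOC(=O)c1c(-c2cccc(Oc3ccccc3)c2)[nH]c2cc(OC)ccc2c1=O`) gives > 21500 nM (limit)
- compound 3 (`CCOC(=O)c1c(-c2cccc(O)c2)[nH]c2cc(OC)ccc2c1=O`) gives > 21500 nM (limit)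

Compound 2 stands at the limit of > 21500 nM in this assay, at which 3 of the 3 values shown sit, and offers no number of its own. Compound 4 (`COc1ccc2c(=O)c(C(=O)OCCCN(C)C)c(-c3cccc(Oc4ccccc4)c3)[nH]c2c1`) carries (dimethylamino)methyl in place of hydrogen on a saturated chain carbon, two bonds along the chain from an oxygen next to a carbonyl group, so ethoxy becomes 3-(dimethylamino)propoxy. The measured steps bear only loosely: a step that the two limits leave unreadable from compound 1 to compound 2 and a step that the two limits leave unreadable from compound 1 to compound 3 and a step that the two limits leave unreadable from compound 2 to compound 3 have no readable size, and none alters that chain. In this assay the expected result is an at least 1.1-fold lower number from compound 2 to compound 4 (0.07 log units; that floor lies within the scatter) with at most a modest move towards smaller amounts. Compound 4 is estimated at 18000 nM within 6000 nM to 40000 nM and may well turn out to be only a limit.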

Compound 4, half-maximal effective concentration: > 21500 nM
Compound 4 was reported as a limit (the forecaster's own chance of this, stated with the estimate: 60%); middle value at least 1.1-fold (0.07 log units) from the limit.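

Compound 2 and compound 4 are both reported only as limits, and no size can be read for the change from ethoxy to 3-(dimethylamino)propoxy. The compounds shown leave open whether any change to this series gives a measurable value in this assay.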